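The source may hold more compounds than are shown below. What is called first, only, known or untested is meant among the compounds shown, and "the series" means these compounds.

Working notes on the series.

Of the compounds shown here, three have been measured in a functional assay on HL-60 cells (Homo sapiens) for antiproliferative activity; on this read-out higher numbers stand for weaker inhibition and lower numbers for stronger inhibition. Compound 1 `COc1cc(OC)cc(-c2ccc(-c3ccc(O)cc3)cc2)c1` gives 2500 nM. Compound 2 `COc1ccc(-c2ccc(-c3cc(OC)cc(OC)c3)cc2)cc1` gives 75000 nM; the change between these two is methyl in place of hydrogen on an oxygen on an aromatic ring, and the step that it made is a 30-fold higher number from compound 1 to compound 2 (1.48 log units; beyond the scatter). Compound 3 `COc1cc(OC)cc(-c2ccccc2-c2ccc(O)cc2)c1` gives 5000 nM. Compound 1 and compound 3 are built from the same atoms joined differently; the difference between the two cores is not broken down here. Compound 3 and compound 1 stand within the scatter of each other, while compound 3 and compound 2 lie apart by more than the scatter, compound 2 carrying the higher number.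

Compound 4 `COc1ccc(-c2ccccc2-c2cc(OC)cc(OC)c2)cc1` has not yet been measured in this assay. It differs from compound 3 by methyl in place of hydrogen on an oxygen on an aromatic ring. The place of this change reads the same, word for word, as the place of the change from compound 1 to compound 2, so it is the same change, now made on the core of compound 3. The change has been seen once so far in the series. Since on the core of compound 1 it produced a 30-fold higher number from compound 1 to compound 2 (1.48 log units; beyond the scatter), a step of similar size is expected on the core of compound 3, though with a single earlier occurrence the spread is kept wide. The expected step here is a 24-fold higher number from compound 3 to compound 4 (1.38 log units; beyond the scatter). For compound 4 in this assay the estimate is 120000 nM, between 30000 nM and 400000 nM.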

Compound 4, half-maximal inhibitory concentration: 7000 nM
Beside the measured number, compound 4's estimate is 17-fold (1.23 log units) above it, outside the stated range (below it).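

In this assay, the change from hydroxy to methoxy, here 4-hydroxyphenyl to 4-methoxyphenyl, gives on the core of compound 3 a much smaller step than on the core of compound 1, namely a 1.4-fold higher number from compound 3 to compound 4 (0.15 log units; within the scatter). The same change therefore does not carry over from one core to the other at the same size: the same change on two cores in this assay, a 30-fold higher number (1.48 log units; beyond the scatter) from compound 1 to compound 2 and a 1.4-fold higher number (0.15 log units; within the scatter) from compound 3 to compound 4, 21-fold (1.33 log units) apart, beyond the scatter of two such steps. This shows that, for these two pairs, the size of the step cannot be read across from one core to the other; it does not show what in the cores sets the gap, and two pairs give no rule for any further core.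

The compounds shown leave open which of the two step sizes would hold on a third core, since only one large and one small step stand side by side. They also leave open how an ethyl group on that same oxygen, or an amine in place of the hydroxy, would read on the core of compound 1 and on the core of compound 3.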